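Thiadiazole for Pyrimidine on the Sulfur, Tried Again

The source may hold more compounds than are shown below. What is called first, only, known or untested is meant among the compounds shown, and "the series" means these compounds.

Compound 2 `O=C(CSc1ncccn1)N/N=c1/scc(-c2ccc(Cl)cc2)n1-c1ccccc1` and compound 1 `Cc1nnc(SCC(=O)N/N=c2/scc(-c3ccc(Cl)cc3)n2-c2ccccc2)s1` share one core and differ in a single place: 5-methyl-1,3,4-thiadiazol-2-yl in place of pyrimidin-2-yl on a sulfur. In a functional assay on C6 cells (Rattus norvegicus) for cytotoxicity, read by MTT assay, with a stated time of 24 h, tested at 50 ug/mL (on this read-out lower numbers stand for a stronger effect and higher numbers for a weaker effect at the one concentration tested), compound 2 gives 61.8% and compound 1 gives 37.9%, a step of a number 23.9 percentage points lower from compound 2 to compound 1 (beyond the scatter). Compound 3 `Cc1ccc(-c2cs/c(=N/NC(=O)CSc3ncccn3)n2-c2ccccc2)cc1` differs from compound 2 by methyl in place of chloro on an aromatic carbon; in this assay compound 3 gives 64.4%, and the change reads a number 2.6 percentage points higher from compound 2 to compound 3 (within the scatter). Compound 4 `Cc1ccc(-c2cs/c(=N/NC(=O)CSc3nnc(C)s3)n2-c2ccccc2)cc1` remains unmeasured and differs from compound 3 by 5-methyl-1,3,4-thiadiazol-2-yl in place of pyrimidin-2-yl on a sulfur, the same kind of change seen between compound 2 and compound 1, at a place described in the same words. For compound 4 the expected step is a number 23.9 percentage points lower from compound 3 to compound 4 (beyond the scatter), resting on the earlier step of a number 23.9 percentage points lower from compound 2 to compound 1 (beyond the scatter) and on the value of compound 3, which is 64.4%. Compound 4 is therefore estimated at 40.5%, with a likely range from 28% to 54%.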

Compound 4, a percentage reported as activity, at one concentration (the size of the read-out at that concentration, not a potency): 40.6%
Compound 4: the middle estimate sits 0.1 percentage points below what was measured, and the stated range covers the measured number.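

In this assay, placing 5-methyl-1,3,4-thiadiazol-2-yl in place of pyrimidin-2-yl on the sulfur gives a number 23.8 percentage points lower from compound 3 to compound 4 (beyond the scatter), so the change carries over to a second core: the same change on two cores in this assay, a number 23.9 percentage points lower (beyond the scatter) from compound 2 to compound 1 and a number 23.8 percentage points lower (beyond the scatter) from compound 3 to compound 4, 0.1 percentage points apart, within the scatter of two such steps Methyl in place of chloro on an aromatic carbon reads a number 2.7 percentage points higher from compound 1 to compound 4 (within the scatter), and that change also matches its earlier counterpart: the same change on two cores in this assay, a number 2.6 percentage points higher (within the scatter) from compound 2 to compound 3 and a number 2.7 percentage points higher (within the scatter) from compound 1 to compound 4, 0.1 percentage points apart, within the scatter of two such steps This holds for these four compounds at a single concentration, on two cores that differ in one group, and it does not show that the step would survive on a core changed elsewhere, nor why it arises.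

Still open, going by these compounds, is whether the step holds with a methoxy group or a nitro group in place of chloro or methyl. Also open, on these data alone, is how an amine on the thiadiazole ring, or a longer chain in place of the methyl on that ring, would read.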